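Aryl-triazole esters of a shared terpenoid core: third analogue

A few compounds are considered here, and "the series" means these few. Any claim that something is new, unique, unknown or untested is made for them only; others in the source may bear on it.

Measured compounds in a functional assay on A549 cells (Homo sapiens) for antiproliferative activity, read by MTT assay, with a stated time of 48 h; on this read-out lower numbers stand for stronger inhibition and higher numbers for weaker inhibition:
- compound 1 `C/C(=C\CC/C(C)=C/CC[C@@H]1[C@@]2(C)CCC(=O)C(C)(C)[C@H]2CC[C@@]1(C)O)CC/C=C(\C)C(=O)OCc1cn(-c2ccc(F)cc2)nn1`: > 150000 nM, a limit of the assay
- compound 2 `C#CCOC(=O)/C(C)=C/CC/C(C)=C/CC/C(C)=C/CC[C@@H]1[C@@]2(C)CCC(=O)C(C)(C)[C@H]2CC[C@@]1(C)O`: 45100 nM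
- compound 3 `C/C(=C\CC/C(C)=C/CC[C@@H]1[C@@]2(C)CCC(=O)C(C)(C)[C@H]2CC[C@@]1(C)O)CC/C=C(\C)C(=O)OCc1cn(-c2cccc(C)c2)nn1`: > 150000 nM, a limit of the assay

Compound 1 stands only at a limit in this assay, with no number of its own. The same limit holds for compound 3, so two of the three values are limits (the limit of > 150000 nM in this assay, at which 2 of the 3 values shown sit). Compound 2 alone gives a number, and the step of an at least 3.3-fold lower number from compound 1 to compound 2 (0.52 log units; beyond the scatter) shows the ester with an ethynyl group reading lower than its aryl-triazole counterpart. The reverse step of an at least 3.3-fold higher number from compound 2 to compound 3 (0.52 log units; beyond the scatter) points the same way. For the measured compounds named here, the one step that moves the aryl group itself, a step that the two limits leave unreadable from compound 1 to compound 3, cannot be read, since both ends are limits.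

Compound 4 `C/C(=C\CC/C(C)=C/CC[C@@H]1[C@@]2(C)CCC(=O)C(C)(C)[C@H]2CC[C@@]1(C)O)CC/C=C(\C)C(=O)OCc1cn(-c2cccc(Br)c2)nn1` differs from compound 1 by 3-bromophenyl in place of 4-fluorophenyl on an aromatic nitrogen. Going by the values given here, the step that bears on it most directly is the one from compound 1 to compound 3, which is unreadable; what both aryl-triazole esters show is that neither reaches a number in this assay. Compound 4 is therefore expected to sit at or near the same limit, and the expected step of a number no higher from compound 1 to compound 4 (the limit leaves the size open) is none readable beyond the scatter. The estimate for compound 4 is 150000 nM, with a range from 60000 nM to 400000 nM.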

Compound 4, half-maximal inhibitory concentration: > 150000 nM
Compound 4 gave a limit, no number (the forecaster's own chance of this, stated with the estimate: 75%); the middle value lies on the limit itself.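

With 3-bromophenyl on the aromatic nitrogen, a third aryl group joins 4-fluorophenyl and 3-methylphenyl in giving no number in this assay, so a bromo-substituted ring changes nothing that can be read at this position; compound 2, the ethynyl ester, is the only compound shown that goes against this pattern. The step of an at least 3.3-fold higher number from compound 2 to compound 4 (0.52 log units; beyond the scatter) extends to a third aryl-triazole ester the gap already seen for compound 1 and compound 3, while the steps among the three aryl-triazole esters cannot be read, since both ends of each are limits. All three aryl-triazole esters now share one limit, so no ranking among their aryl groups is possible: the limit of > 150000 nM in this assay, at which 3 of the 4 values shown sit.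

The compounds shown leave open whether any aryl group on this ring nitrogen can bring the series to a readable number in this assay, for example a phenyl ring carrying an amine or a carboxylic acid. They also leave open whether a longer chain in place of ethynyl, with no aryl-triazole at all, would keep a number like that of compound 2.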